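A few compounds are considered here, and "the series" means these few. Any claim that something is new, unique, unknown or untested is made for them only; others in the source may bear on it.

Measured so far in an assay on isolated protein for inhibition of Aromatase (Homo sapiens), read by ELISA, using NADPH, with a stated time of 24 h; on this read-out higher numbers stand for weaker inhibition and lower numbers for stronger inhibition:
Compound 1 `Fc1ccc(-c2[nH]c3cc(Cl)ccc3c2Cn2ccnc2)cc1` gives 32.3 nM.
Compound 2 `Clc1ccc(-c2[nH]c3cc(Cl)ccc3c2Cn2ccnc2)cc1` gives 261 nM.
Compound 3 `COc1ccc(-c2[nH]c3cc(Cl)ccc3c2Cn2ccnc2)cc1` gives 277 nM.

Among these three, compound 2 holds the second highest number. Its nearest neighbour is compound 3, whose value is within the scatter of it, so no order between them can be claimed; the step of a 1.1-fold higher number from compound 2 to compound 3 (0.03 log units; within the scatter) says the same. Its furthest neighbour is compound 1, and the step of an 8.1-fold higher number from compound 1 to compound 2 (0.91 log units; beyond the scatter) is well beyond the scatter, as is an 8.6-fold higher number from compound 1 to compound 3 (0.93 log units; beyond the scatter).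

Compound 4 `COc1ccc2c(Cn3ccnc3)c(-c3ccc(Cl)cc3)[nH]c2c1` is not yet measured. It differs from compound 2 in one place: methoxy in place of chloro on an aromatic carbon. For the measured compounds named here, the one measured step with the same exchange, a 1.1-fold higher number from compound 2 to compound 3 (0.03 log units; within the scatter), stayed within the scatter, but there the exchange happened at a different place in the molecule, not in the fused system, so it bears on this step only loosely. The steps from compound 1 show that a change on an aromatic carbon can move the number well beyond the scatter, which widens the uncertainty. On balance, no step beyond the scatter is expected in this assay from compound 2 to compound 4, that is a 1.0-fold lower number from compound 2 to compound 4 (0.02 log units; within the scatter). For compound 4 the value is therefore estimated at 250 nM, in the range 70 nM to 900 nM.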

Compound 4, half-maximal inhibitory concentration: 1060 nM
The estimate for compound 4 lay 4.2-fold (0.63 log units) below the measured number, and the stated range ends below it.
By their numbers in this assay, from the lowest: compound 1; then compounds 2 and 3 (each within the scatter of the next); then compound 4.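

In this assay, methoxy in place of chloro on an aromatic carbon of the fused system is not a neutral exchange: it gives a 4.1-fold higher number from compound 2 to compound 4 (0.61 log units; beyond the scatter), whereas the same exchange at a different place in the molecule gave a 1.1-fold higher number from compound 2 to compound 3 (0.03 log units; within the scatter). The two steps together show that the effect of this exchange depends on where it happens, and that inhibition at this position of the fused system is weaker with methoxy than with chloro, something compound 3 alone could not reveal. Nothing available here explains why the exchange matters at this position and not at the other one.

As far as these compounds go, only chloro and methoxy appear at this position, so two points remain open: whether chloro is especially favourable here or methoxy especially unfavourable, and how far the number would move with a different group. A hydroxyl group or an amine at the same carbon, compared directly with compound 2, would begin to answer this, and a fluoro group there would show whether the advantage of compound 1 over compound 2 on the other ring has any counterpart in the fused system.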